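Adding a nitro group to the ethoxy compound

The compounds below may be only part of what the source reports. "The series", "measured", "known", "first", "only" and "open" are said of these compounds alone.

Among the measured compounds shown here, in a functional assay on the whole organism (strain Sprague-Dawley) for inhibition, with Rattus norvegicus as the target, with a stated time of 10 min (a lower number here means that less compound is needed, a higher number that more compound is needed for the effect), compound 2 `CCOC(=O)c1cnc(-c2ccccc2OCC)[nH]c1=O` gives 2 mg/kg, the only actual number among the three measured compounds. Compound 1 `CCOC(=O)c1cnc(-c2ccccc2F)[nH]c1=O` gives > 10 mg/kg, which is a limit. Compound 3 `CCOC(=O)c1cnc(-c2ccccc2SCC)[nH]c1=O` gives > 5 mg/kg, also a limit. Compound 4 `CCOC(=O)c1cnc(-c2cc([N+](=O)[O-])ccc2OCC)[nH]c1=O` carries nitro in place of hydrogen on an aromatic carbon, with nitro in place of hydrogen, para to an ethoxy group. For the measured compounds named here, two measured steps bear on this change only indirectly: an at least 5.0-fold lower number from compound 1 to compound 2 (0.69 log units; beyond the scatter) and an at least 2.5-fold higher number from compound 2 to compound 3 (0.39 log units; beyond the scatter). Each swaps one group for another, and neither adds nitro. No firm direction can be drawn from them, so the expected step is small, within the scatter: a 1.3-fold higher number from compound 2 to compound 4 (0.10 log units; within the scatter). The estimate for compound 4 is 2.5 mg/kg, with an expected range from 0.6 mg/kg to 10 mg/kg.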

Compound 4, dose for 50% inhibition: 5 mg/kg
The estimate for compound 4 lay 2.0-fold (0.30 log units) below the measured number; measured number inside the range.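

Compound 4 shows that this position, para to an ethoxy group, can be changed with the effect retained at a cost: nitro in place of hydrogen gives a 2.5-fold higher number from compound 2 to compound 4 (0.40 log units; beyond the scatter) in this assay. Among the compounds shown here, the earlier compounds varied only the ethoxy group itself, so this is the first reading of a change elsewhere on that ring. Nothing measured here gives a reason for this step.

From the compounds shown here alone, whether an amine or a carboxylic acid at this position would give the same step remains open. So does whether nitro would have the same effect with fluoro or ethylsulfanyl in place of ethoxy.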